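A few compounds are considered here, and "the series" means these few. Any claim that something is new, unique, unknown or untested is made for them only; others in the source may bear on it.

Compound 3 `COc1ccc(C(=O)/C=C/c2cc(-c3cc(OC)c(OC)c(OC)c3)n[nH]2)cc1OC` was tested in a functional assay on HCC 2998 cells (Homo sapiens) for cytotoxicity, read by sulforhodamine B assay, with a stated time of 48 h, tested at 100 uM (a higher number here means a weaker effect of the compound at the concentration tested, a lower number a stronger effect), where compound 3 gives -86%. Its two measured relatives are compound 1 `COc1ccc(-c2cc(/C=C/C(=O)c3cc(OC)c(OC)c(OC)c3)[nH]n2)cc1OC`, which in this assay gives -82%, and compound 2 `COc1ccc(C(=O)/C=C/c2cc(-c3cc(OC)c(OC)c(OC)c3)n[nH]2)cc1`, which gives -82%; all three numbers sit within the scatter of one another, so compound 3 stands level with both. Compound 4 `COc1cc(C(=O)/C=C/c2cc(-c3cc(OC)c(OC)c(OC)c3)n[nH]2)cc(OC)c1OC` differs from compound 3 by methoxy in place of hydrogen on an aromatic carbon. Among the compounds with values here, the one measured step of this kind, a number 4 percentage points lower from compound 2 to compound 3 (within the scatter), stayed within the scatter. For compound 4 the change is therefore expected to bring no shift beyond the scatter, a step of a number 1 percentage points higher from compound 3 to compound 4 (within the scatter), and compound 4 is estimated at -85%, in a range from -95% to -70%.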

Compound 4, a percentage reported as activity, at one concentration (the size of the read-out at that concentration, not a potency): -89%
For compound 4 the middle estimate is 4 percentage points above the measured one; measured number inside the range.
By their numbers in this assay, from the lowest: compounds 4, 3, 1 and 2 (each within the scatter of the next).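

Methoxy in place of hydrogen on an aromatic carbon, here ortho to a methoxy group, again brings no shift beyond the scatter in this assay, with a number 3 percentage points lower from compound 3 to compound 4 (within the scatter). On another core, the same change gives a number 7 percentage points lower from compound 1 to compound 4 (within the scatter). The change now reads alike on two cores: the same change on two cores in this assay, a number 4 percentage points lower (within the scatter) from compound 2 to compound 3 and a number 7 percentage points lower (within the scatter) from compound 1 to compound 4, 3 percentage points apart, within the scatter of two such steps

All four compounds carry only methoxy groups at the positions that vary, and at this single concentration the read-out does not separate them. On these data alone, what an amine or a carboxylic acid at this position would do stays open, as does whether any of the four compounds has a stronger or weaker effect at this concentration.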